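This account rests on a few compounds, and the source may have more. Where it says the series, first, only, none or still open, it means among the compounds named here.

Compound 1 `Clc1ccc(NCCNc2ccnc3cc(Cl)ccc23)c(Cl)c1`: > 100 ug/mL
Compound 2 `Clc1ccc2c(NCCNc3ccc(Br)cc3)ccnc2c1`: > 100 ug/mL

Both compounds were tested in a toxicity assay on Huh-7 cells (Homo sapiens) for cytotoxicity, read by MTT assay, with a stated time of 72 h; a higher number here means that more compound is tolerated, a lower number that less compound is tolerated. Compound 1 reads > 100 ug/mL, which is a limit of the assay and not a number. Compound 2 reads > 100 ug/mL, which is also a limit. Compound 1 therefore has no exact value, and its position is this: the limit of > 100 ug/mL in this assay, at which 2 of the 2 values shown sit.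

Compound 3 `Clc1ccc(NCCNc2ccnc3cc(Cl)ccc23)cc1` differs from compound 1 in one place, where hydrogen replaces chloro on an aromatic carbon: hydrogen in place of chloro on an aromatic carbon. Going by the values given here, no measured pair of compounds shows what a single change does in this assay, so the expectation is a cautious one. It rests on compound 1 with its limit of > 100 ug/mL. No shift in either direction beyond the scatter is expected. The estimated change is a number no higher from compound 1 to compound 3 (the limit leaves the size open). For compound 3 the expected value is 100 ug/mL, with an estimated range from 50 ug/mL to 200 ug/mL.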

Compound 3, half-maximal cytotoxic concentration: > 100 ug/mL
Compound 3 ended at the assay's limit (the forecaster's own chance of this, stated with the estimate: 70%); the middle value sits exactly at the limit.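

No step can be read between compound 1, compound 2 and compound 3, whose results are all limits and not numbers: the limit of > 100 ug/mL in this assay, at which 3 of the 3 values shown sit.
In this assay, going by these compounds, it stays open what the actual tolerated concentration of each compound is, and whether hydrogen, chloro or bromo on the aromatic carbon makes any difference.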